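This account rests on a few compounds, and the source may have more. Where it says the series, first, only, none or still open, it means among the compounds named here.

Compound 1, `O=C(c1ccncc1)N1N=C(c2cc3ccccc3o2)CC1c1ccccc1O`, in an ADME assay on Vero cells (Chlorocebus sabaeus) for cytotoxicity, read by MTT assay, with a stated time of 72 h (a lower number here means a stronger inhibitor, a higher number a weaker inhibitor), gives > 195000 nM, which is a limit of the assay and not a number.
Compound 2, `COc1ccccc1C1CC(c2cc3ccccc3o2)=NN1C(=O)c1ccncc1`, in this assay gives > 202000 nM, likewise a limit.
Compound 3, `O=C(c1ccncc1)N1N=C(c2cc3ccccc3o2)CC1c1ccc(O)cc1`, in this assay gives > 200000 nM, also a limit.

Compound 3 thus stands at one of three limits; the two other values shown are limits as well, so no order among the three compounds can be read. The steps a step that the two limits leave unreadable from compound 1 to compound 2, a step that the two limits leave unreadable from compound 1 to compound 3 and a step that the two limits leave unreadable from compound 2 to compound 3 are all unreadable, since each runs between two limits, as the limit of > 195000 nM in this assay, at which 1 of the 3 values shown sits, the limit of > 200000 nM in this assay, at which 1 of the 3 values shown sits, and the limit of > 202000 nM in this assay, at which 1 of the 3 values shown sits, show. The change now followed is 2-nitrophenyl in place of 4-hydroxyphenyl on a saturated ring carbon, giving compound 4, `O=C(c1ccncc1)N1N=C(c2cc3ccccc3o2)CC1c1ccccc1[N+](=O)[O-]`. The measured step closest to it is a step that the two limits leave unreadable from compound 2 to compound 3, also an exchange of the aryl group on the saturated ring carbon, but its size is not readable. Compound 4 is therefore expected to sit at the same limit, with the step of a number no higher from compound 3 to compound 4 (the limit leaves the size open) expected not to be readable beyond the scatter, and no direction is supported by the data. The estimate for compound 4 in this assay is 200000 nM, within a range of 60000 nM to 400000 nM.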

Compound 4, half-maximal inhibitory concentration: > 245000 nM
Compound 4: no number, only a limit; the forecaster's own chance of this, stated with the estimate: 80%; middle value at least 1.2-fold (0.08 log units) away from the limit.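

In this assay compound 4 gives > 245000 nM, a limit of the assay and not a number. The steps to it from compound 1, compound 2 and compound 3 cannot be read, as each runs between two limits: the limit of > 245000 nM in this assay, at which 1 of the 4 values shown sits.

The compounds shown leave open any order among them in this assay and whether exchanging the aryl group on the saturated ring carbon changes the value at all.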